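The source may hold more compounds than are shown below. What is called first, only, known or untested is meant among the compounds shown, and "the series" means these compounds.

Compound 1 `NS(=O)(=O)c1ccc(Nc2ncc(F)c(Nc3nc4ccccc4s3)n2)cc1` gives 22600 nM in a functional assay on MDA-MB-231 cells (Homo sapiens) for antiproliferative activity, read by MTT assay, with a stated time of 48 h; on this read-out lower numbers stand for stronger inhibition and higher numbers for weaker inhibition.
Compound 2 `COc1ccc2nc(Nc3nc(Nc4ccc(S(N)(=O)=O)cc4)ncc3F)sc2c1` gives 26600 nM in this assay.
Compound 3 `COc1ccc2nc(Nc3ccnc(Nc4ccc(S(N)(=O)=O)cc4)n3)sc2c1` gives 6240 nM in this assay.

Two single-point changes connect these measured compounds. From compound 2 to compound 1 the change is hydrogen in place of methoxy on an aromatic carbon, and in this assay it made a 1.2-fold lower number from compound 2 to compound 1 (0.07 log units; within the scatter). The other change, from compound 2 to compound 3, made a 4.3-fold lower number from compound 2 to compound 3 (0.63 log units; beyond the scatter), which leaves compound 3 with the lowest number of the three.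

Compound 4 `NS(=O)(=O)c1ccc(Nc2nccc(Nc3nc4ccccc4s3)n2)cc1` has not yet been measured. It differs from compound 3 by hydrogen in place of methoxy on an aromatic carbon, the same change as that from compound 2 to compound 1; the cores of the two pairs differ by hydrogen in place of fluoro on an aromatic carbon. Because a 1.2-fold lower number from compound 2 to compound 1 (0.07 log units; within the scatter) lay within the scatter, compound 4 is expected to sit close to compound 3, an expected step of a 1.2-fold lower number from compound 3 to compound 4 (0.08 log units; within the scatter). Compound 4 is estimated at 5200 nM, with a likely range from 2600 nM to 10500 nM.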

Compound 4, half-maximal inhibitory concentration: 5000 nM
Estimate against measurement, compound 4: 1.0-fold (0.02 log units) above; low and high end bracket the measured number.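

Hydrogen in place of methoxy gives a 1.2-fold lower number from compound 3 to compound 4 (0.10 log units; within the scatter) in this assay, and this small step carries over between the cores with and without fluoro: the same change on two cores in this assay, a 1.2-fold lower number (0.07 log units; within the scatter) from compound 2 to compound 1 and a 1.2-fold lower number (0.10 log units; within the scatter) from compound 3 to compound 4, 1.1-fold (0.03 log units) apart, within the scatter of two such steps. Hydrogen in place of fluoro gives a 4.5-fold lower number from compound 1 to compound 4 (0.66 log units; beyond the scatter), and this larger step likewise carries over between the cores with and without methoxy: the same change on two cores in this assay, a 4.3-fold lower number (0.63 log units; beyond the scatter) from compound 2 to compound 3 and a 4.5-fold lower number (0.66 log units; beyond the scatter) from compound 1 to compound 4, 1.1-fold (0.03 log units) apart, within the scatter of two such steps. Across these four compounds the two changes therefore add up independently, but this rests on a single square of compounds in one assay and does not show why the fluoro change matters.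

The compounds shown leave open whether chloro or an amine in place of fluoro, or ethoxy in place of methoxy, would follow the same pattern.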